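A Carboxylated Pyridine Replaces the Cyanophenyl Group

This account rests on a few compounds, and the source may have more. Where it says the series, first, only, none or still open, it means among the compounds named here.

Three compounds share one core and differ only in the aromatic group attached to it. Compound 1 `O=C(CCCCCCc1ccccc1)c1ncc(-c2ccccc2F)o1` carries a 2-fluorophenyl group, compound 2 `N#Cc1ccccc1-c1cnc(C(=O)CCCCCCc2ccccc2)o1` a 2-cyanophenyl group, and compound 3 `O=C(O)c1ccc(-c2cnc(C(=O)CCCCCCc3ccccc3)o2)cc1` a 4-carboxyphenyl group. In an assay (Rattus norvegicus) for inhibition of Fatty-acid amide hydrolase 1 (Homo sapiens) (on this read-out higher numbers stand for weaker inhibition and lower numbers for stronger inhibition), compound 1 gives 110 nM, compound 2 gives 130 nM and compound 3 gives 60 nM. Compound 2 therefore has the highest number of the three; the step of a 1.2-fold higher number from compound 1 to compound 2 (0.07 log units; within the scatter) lies within the scatter, while the step of a 2.2-fold lower number from compound 2 to compound 3 (0.34 log units; beyond the scatter) is a modest but real change. Compound 4 `O=C(CCCCCCc1ccccc1)c1ncc(-c2ncccc2C(=O)O)o1` has not yet been measured. It differs from compound 2 in one place: 3-carboxypyridin-2-yl in place of 2-cyanophenyl on an aromatic carbon. The nearest guide is the step of a 2.2-fold lower number from compound 2 to compound 3 (0.34 log units; beyond the scatter), in which a carboxylic acid likewise entered in place of the nitrile and the number fell. The additional ring nitrogen of compound 4 has no measured counterpart among these compounds, so its contribution is unknown. A modest fall in this assay is therefore expected, a 1.9-fold lower number from compound 2 to compound 4 (0.27 log units; within the scatter). Compound 4 is estimated at 70 nM, with a range from 30 nM to 160 nM.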

Compound 4, inhibition constant: > 50 nM
Compound 4: only a limit was reported (the forecaster's own chance of this, stated with the estimate: 3%); the middle value does not contradict the limit.
By their numbers in this assay, from the lowest: compounds 3, 1 and 2 (each within the scatter of the next, the first and the last beyond it).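

In this assay compound 4 gives > 50 nM, which is a limit and not a number. Its steps from compound 1, compound 2 and compound 3 therefore cannot be read. The compounds shown leave open where compound 4 stands relative to these three, and what the ring nitrogen of its 3-carboxypyridin-2-yl group contributes.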